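Sulfur substituent change on the shared core: compound 4

The source may report more compounds than this note shows. Statements on the series, on what has been measured and on what is new or still open speak of the compounds shown alone.

Measured compounds:
compound 1 `CSc1nnc(COc2cc(C)c3c(C)cc(=O)oc3c2)o1` — > 100000 nM, a limit of the assay
compound 2 `CCCCCSc1nnc(COc2cc(C)c3c(C)cc(=O)oc3c2)o1` — > 100000 nM, a limit of the assay
compound 3 `Cc1cc(OCc2nnc(SCc3ccc(Cl)cc3Cl)o2)cc2oc(=O)cc(C)c12` — > 100000 nM, a limit of the assay

In a functional assay on MDA-MB-231 cells (Homo sapiens) for antiproliferative activity, read by MTT assay, with a stated time of 24 h (a higher number here means a weaker inhibitor, a lower number a stronger inhibitor), compound 1 gives > 100000 nM, which is a limit of the assay and not a number. Compound 2 likewise returns a limit, > 100000 nM. Compound 3 also returns a limit, > 100000 nM. Compound 1 therefore stands nowhere measurable on the numbers shown: its value is a limit, and so are the two other values, as the limit of > 100000 nM in this assay, at which 3 of the 3 values shown sit, records. The measured steps, a step that the two limits leave unreadable from compound 1 to compound 2, a step that the two limits leave unreadable from compound 1 to compound 3 and a step that the two limits leave unreadable from compound 2 to compound 3, all concern the saturated chain carbon bound to a sulfur and none has a readable size.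

Compound 4 `CCCS(=O)(=O)c1nnc(COc2cc(C)c3c(C)cc(=O)oc3c2)o1` differs from compound 1 at another place: propylsulfonyl in place of methylsulfanyl on an aromatic carbon. Within the data shown here, no measured step touches the aromatic carbon of the five-membered aromatic ring, so nothing bears directly on this change.

Compound 1 gives only a limit, > 100000 nM. On that basis compound 4 is expected to sit at the same limit, so that a number no higher from compound 1 to compound 4 (the limit leaves the size open) is expected to remain unreadable. The estimate for compound 4 is 100000 nM, between 30000 nM and 300000 nM, most probably reported as a limit.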

Compound 4, half-maximal inhibitory concentration: 7070 nM
For compound 4 the middle estimate is 14-fold (1.15 log units) above the measured one; the measured number lies below the stated range.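

In this assay, among these compounds, the aromatic carbon of the five-membered aromatic ring is the first place where a change gives a readable step, with propylsulfonyl in place of methylsulfanyl (an at least 14-fold lower number from compound 1 to compound 4 (1.15 log units; beyond the scatter)). On these data alone, the same holds with propylsulfonyl in place of pentylsulfanyl (an at least 14-fold lower number from compound 2 to compound 4 (1.15 log units; beyond the scatter)) and in place of (2,4-dichlorobenzyl)sulfanyl (an at least 14-fold lower number from compound 3 to compound 4 (1.15 log units; beyond the scatter)), and each of these sizes is bounded by a limit of the assay, so the true gap stays open on one side. The steps among compound 1, compound 2 and compound 3 cannot be read, so the three sulfanyl groups cannot be ranked against one another: the limit of > 100000 nM in this assay, at which 3 of the 4 values shown sit.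

The change to compound 4 combines the sulfonyl group with a different chain on sulfur, and the compounds shown do not separate these two parts. Methylsulfonyl and propylsulfanyl at this carbon would tell them apart, while a longer chain on the sulfonyl, or an amine in its place, remains an open question for how far this position can be pushed in this assay.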